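A few compounds are considered here, and "the series" means these few. Any claim that something is new, unique, unknown or untested is made for them only; others in the source may bear on it.

Values in an ADME assay on BJ cells (Homo sapiens), read by MTT assay, with a stated time of 72 h; a lower number here means a stronger inhibitor, a higher number a weaker inhibitor:
- compound 1 `COc1ncnc2c1c(-c1ccccc1)cn2[C@@H]1O[C@H](CO)[C@@H](O)[C@H]1O`: > 100000 nM (a limit of the assay, not a number)
- compound 2 `C#Cc1cn([C@@H]2O[C@H](CO)[C@@H](O)[C@H]2O)c2ncnc(OC)c12`: 98400 nM
- compound 3 `C#Cc1cn([C@@H]2O[C@H](CO)[C@@H](O)[C@H]2O)c2ncnc(C)c12`: 50 nM

Compound 2 has the higher of the two actual numbers, and its nearest neighbour is compound 3, with a 2000-fold lower number from compound 2 to compound 3 (3.29 log units; beyond the scatter). Compound 4 `C#Cc1cn([C@@H]2O[C@H](CO)[C@@H](O)[C@H]2O)c2nc(N)nc(OC)c12` differs from compound 2 by one change: amino in place of hydrogen on an aromatic carbon, amino in place of hydrogen, between two ring nitrogen atoms. Within the data shown here, no measured step makes this change. The ethynyl change gives an at least 1.0-fold lower number from compound 1 to compound 2 (0.00 log units; that floor lies within the scatter), only a floor. The methyl change gives a 2000-fold lower number from compound 2 to compound 3 (3.29 log units; beyond the scatter), which is large but is a different change. No step beyond the scatter is therefore expected in this assay. The estimated step is a 1.2-fold lower number from compound 2 to compound 4 (0.09 log units; within the scatter). The expected value for compound 4 is 80000 nM, with an estimated range of 15000 nM to 100000 nM.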

Compound 4, half-maximal inhibitory concentration: > 100000 nM
Compound 4: a limit, no number (the forecaster's own chance of this, stated with the estimate: 50%); middle value at least 1.2-fold (0.09 log units) from the limit.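

In this assay, amino in place of hydrogen, between two ring nitrogen atoms, gives an at least 1.0-fold higher number from compound 2 to compound 4 (0.00 log units; that floor lies within the scatter). Compound 4 gives > 100000 nM, a limit of the assay and not a number. With methoxy on the ring, amino at this position therefore brings no drop in the number, and the size of any rise cannot be read: the limit of > 100000 nM in this assay, at which 2 of the 4 values shown sit.

Open, as far as these compounds go, is what amino at this position does alongside the methyl group of compound 3, which gives 50 nM. Also open, from the compounds shown here alone, is how a methylamino group or a chlorine atom would read at this position.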